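The source may hold more compounds than are shown below. What is called first, only, known or untested is meant among the compounds shown, and "the series" means these compounds.

Measured in an ADME assay on Akata cells (Homo sapiens) for cytotoxicity, with a stated time of 7 days; on this read-out higher numbers stand for lower toxicity in this test and lower numbers for higher toxicity in this test (each entry is a limit of the assay and not a number):
compound 1 `CCCCCCCCSc1nc(N)nc2c1ncn2/C=C1/CC1(CO)CO` gives > 20000 nM
compound 2 `Nc1nc(NC2CCCCC2)c2ncn(/C=C3/CC3(CO)CO)c2n1` gives > 24000 nM
compound 3 `CCCCCOc1nc(N)nc2c1ncn2/C=C1/CC1(CO)CO` gives > 20000 nM

For the measured compounds named here, the series so far rests on two limits: the limit of > 20000 nM in this assay, at which 2 of the 3 values shown sit, and (the limit of > 24000 nM in this assay, at which 1 of the 3 values shown sits). Compound 3 has only a limit, > 20000 nM, so its place relative to the other two cannot be read.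

The next compound is compound 4 `CCCCNc1nc(N)nc2c1ncn2/C=C1/CC1(CO)CO`, with butylamino in place of pentyloxy on an aromatic carbon. The measured change closest to this one is a step that the two limits leave unreadable from compound 2 to compound 3, since compound 2 carries cyclohexylamino. Also bearing on it are a step that the two limits leave unreadable from compound 1 to compound 3 and a step that the two limits leave unreadable from compound 1 to compound 2. Going by the values given here, none of these steps gives a size or a direction, and no measured pair isolates butylamino against pentyloxy.

With only limits to go on, the expectation in this assay is for no step beyond the scatter, and a step that the limit leaves unreadable from compound 3 to compound 4 is the estimated step. Another limit is the most likely report. For compound 4 the estimated value is 24000 nM, with an expected range from 10000 nM to 60000 nM.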

Compound 4, half-maximal cytotoxic concentration: > 24000 nM
Compound 4 was reported as a limit; the forecaster's own chance of this, stated with the estimate: 80%; the middle value lies on the limit itself.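

In this assay compound 4 gives > 24000 nM, a limit of the assay and not a number. No step from compound 1, compound 2 or compound 3 to compound 4 can be read, since all four entries are limits: the limit of > 24000 nM in this assay, at which 2 of the 4 values shown sit.

As far as these compounds go, whether butylamino, pentyloxy, cyclohexylamino and octylsulfanyl on the shared core differ at all in this assay stays open.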